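From Nitro to Trifluoromethyl on Compound 1

The source may report more compounds than this note shows. Statements on the series, on what has been measured and on what is new or still open speak of the compounds shown alone.

In a functional assay on DU-145 cells (Homo sapiens) for inhibition, read by trypan blue exclusion, with a stated time of 96 h (on this read-out higher numbers stand for weaker inhibition of growth and lower numbers for stronger inhibition of growth), three compounds have been measured so far. Compound 1 (`O=C(/C(=C\c1ccc([N+](=O)[O-])c(O)c1)SCc1ccc(Br)cc1)c1ccc([N+](=O)[O-])cc1`) gives 1000 nM and holds the lowest number of the three. Compound 2 (`O=C(/C(=C\c1ccc(O)c([N+](=O)[O-])c1)SCc1ccc(Br)cc1)c1c(F)c(F)c(F)c(F)c1F`) gives 10000 nM and lies beyond the scatter from compound 1. Compound 3 (`Cc1ccc(CS(=O)(=O)/C(=C/c2ccc(Br)cc2)C(=O)c2ccc(Cl)cc2)cc1`) gives 25000 nM and also lies beyond the scatter from compound 1.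

Still to be measured is compound 4 (`O=C(/C(=C\c1ccc([N+](=O)[O-])c(O)c1)SCc1ccc(Br)cc1)c1ccc(C(F)(F)F)cc1`), which keeps the core of compound 1 and changes one group. Trifluoromethyl stands in place of nitro on an aromatic carbon, para to a large group, so that 4-nitrophenyl becomes 4-(trifluoromethyl)phenyl (trifluoromethyl in place of nitro on an aromatic carbon). Going by the values given here, no two measured compounds differ in only one place, so the data offer no direct precedent for this exchange.

The expectation therefore starts from compound 1 at 1000 nM and assumes that a single group exchange moves the number only modestly. The expected change is a 1.5-fold higher number from compound 1 to compound 4 (0.18 log units; within the scatter) in this assay, a small move toward weaker inhibition that is not expected to clear the scatter. For compound 4 the estimated value is 1500 nM, with an expected range from 500 nM to 6000 nM when it is measured.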

Compound 4, concentration for 50% growth inhibition: 1000 nM
Estimate against measurement, compound 4: 1.5-fold (0.18 log units) above, and the stated range covers the measured number.
By their numbers in this assay, from the lowest: compounds 1 and 4 (each within the scatter of the next); then compound 2; then compound 3.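

In this assay, going by these compounds alone, the exchange of nitro for trifluoromethyl on an aromatic carbon, para to a large group, gives the first comparison in which only one place differs, and it reads no change at the digits printed from compound 1 to compound 4 (within the scatter). The earlier compounds shown here could not show this, since no two of them differed in only one place; this pair shows that, on the core of compound 1, 4-nitrophenyl can give way to 4-(trifluoromethyl)phenyl with the growth-inhibition number staying within the scatter, even though nitro counts hydrogen-bond acceptors and a double bond and trifluoromethyl counts neither. Nothing measured here explains why the two groups read alike.

As far as these compounds go, this is a single pair at a single position, so it remains open whether other groups in the same place, such as an amine, a carboxylic acid or a longer alkyl chain, would also leave the number within the scatter. From the compounds shown here alone, it also remains open whether the same exchange would read alike on a different core, or at another aromatic carbon of compound 1.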